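The source may report more compounds than this note shows. Statements on the series, on what has been measured and on what is new or still open speak of the compounds shown alone.

Of the compounds shown here, three sharing one core have been tested in a functional assay on PC-3 cells (Homo sapiens); on this read-out lower numbers stand for stronger inhibition of growth and higher numbers for weaker inhibition of growth. Compound 1 `Cc1ccnc2nc(-c3ccc(F)cc3)cc(O)c12` gives 51300 nM. Compound 2 `COc1ccccc1-c1cc(O)c2cc(C)cnc2n1` gives 26900 nM. Compound 3 `COc1cccc(-c2cc(O)c3c(C)cc(C)nc3n2)c1` gives 309 nM. Among these three numbers compound 2 holds the second highest; its nearest neighbour is compound 1, whose number sits within the usual scatter of it, while compound 3 lies far lower, well beyond the scatter.

Compound 4 `COc1ccccc1-c1cc(O)c2cccnc2n1` has not yet been measured. It differs from compound 2 in one place: hydrogen in place of methyl on an aromatic carbon. Among the compounds with values here, no pair of measured compounds shows this change on its own, so there is no measured step to lean on. Since a single methyl is removed and the rest of compound 2 is kept, the step of a 1.3-fold higher number from compound 2 to compound 4 (0.11 log units; within the scatter) is expected to be small, with no clear direction and probably not beyond the scatter. Compound 4 is therefore estimated to give 35000 nM, within a range from 12000 nM to 100000 nM.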

Compound 4, concentration for 50% growth inhibition: 29500 nM
For compound 4 the middle estimate is 1.2-fold (0.07 log units) above the measured one, and the stated range covers the measured number.
By their numbers in this assay, from the lowest: compound 3; then compounds 2, 4 and 1 (each within the scatter of the next).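

Replacing methyl with hydrogen on this aromatic carbon, two atoms from the ring nitrogen, gives a 1.1-fold higher number from compound 2 to compound 4 (0.04 log units; within the scatter) in this assay. Within the data shown here, this is the first measured step for this change, and it shows that, with the rest of compound 2 kept, the two compounds cannot be told apart at this position. Nothing available accounts for this result.

The result rests on a single pair, so it cannot show whether the methyl would count for as little with a different group on the outer ring of the shared core. It also leaves open whether something other than methyl or hydrogen on this carbon, such as an amine, a carboxylic acid or a longer chain, would move the number beyond the scatter.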